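A few compounds are considered here, and "the series" means these few. Any claim that something is new, unique, unknown or untested is made for them only; others in the source may bear on it.

Compound 1 `Cc1ccccc1-c1cc(C#Cc2ccc(CCC(=O)O)cc2)ccn1` and compound 2 `O=C(O)CCc1ccc(C#Cc2ncccc2[N+](=O)[O-])cc1` are the two measured compounds in this set, both tested in an in vitro functional assay on 1321-N1 cells for agonist activity at Free fatty acid receptor 1 (Homo sapiens), read by fluorescence, spectrophotometry and calcium flux; on this read-out higher numbers stand for an effect only at larger amounts of compound and lower numbers for an effect already at smaller amounts. On that read-out compound 1 gives 1070 nM, the lower of the two numbers, while compound 2 gives 11000 nM, a gap between them that lies well beyond the usual scatter. Compound 1 therefore stands as the more active of the pair.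

Compound 3 `Cc1cc(C#Cc2ccc(CCC(=O)O)cc2)ccn1` has not yet been measured. It differs from compound 1 in a single respect: methyl in place of 2-methylphenyl on an aromatic carbon, that is, a methyl in place of 2-methylphenyl on an aromatic carbon of the core shared with compound 1. For the measured compounds named here, no step of this kind between two measured compounds is available, so the expected size can rest only on the general picture that the two measured compounds give. Compound 3 is estimated to show a weaker response, with a step of a 5.6-fold higher number from compound 1 to compound 3 (0.75 log units; beyond the scatter) that lies beyond the scatter. The expected value for compound 3 in this assay is 6000 nM, with a range from 2000 nM to 20000 nM.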

Compound 3, half-maximal effective concentration: 1120 nM
Beside the measured number, compound 3's estimate is 5.4-fold (0.73 log units) above it; the whole stated range lies above it.
By their numbers in this assay, from the lowest: compounds 1 and 3 (each within the scatter of the next); then compound 2.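

Replacing 2-methylphenyl with methyl on an aromatic carbon next to the ring nitrogen gives, in this assay, a 1.0-fold higher number from compound 1 to compound 3 (0.02 log units; within the scatter), so this read-out does not separate the two compounds. The earlier comparison of compound 1 with compound 2 could not show this, since those two differ in more than one place; this pair shows that, on the core of compound 1, the six-membered aromatic ring of carbon only can give way to a single carbon at this position with no change beyond the scatter. Nothing at hand gives a measured reason why the two groups read alike.

What the compounds shown leave open is whether this insensitivity extends to groups of another kind at this position, such as an amine, a carboxylic acid or a longer chain, or to a bare hydrogen, since methyl and 2-methylphenyl are the only two groups compared here and both are built of carbon alone. On these data alone, it also stays open whether the same swap would read alike on a different core, as this single pair speaks only for the core shared by compound 1 and compound 3.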